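Removing the Hydroxypyrrolidine from Compound 2

The source may report more compounds than this note shows. Statements on the series, on what has been measured and on what is new or still open speak of the compounds shown alone.

Measured compounds:
compound 1 `COc1ccc(-c2c(C)[nH]c(=O)c3c(N)nn(C)c23)cc1` — 25%
compound 2 `Cc1cc2c(c(N)nn2C)c(N2CC[C@H](O)C2)n1` — 4%

In an assay on isolated protein for inhibition of RAC-beta serine/threonine-protein kinase (Homo sapiens), read by mobility shift assay, tested at 30 uM (on this read-out higher numbers stand for more inhibition at the one concentration tested (going by the name of the read-out) and lower numbers for less inhibition), compound 1 gives 25%, and compound 2 gives 4%. Compound 2 stands lowest of the two numbers; its nearest neighbour is compound 1, whose number lies higher by a margin beyond the usual scatter.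

Compound 3 `Cc1cc2c(cn1)c(N)nn2C` has not yet been measured in this assay. It differs from compound 2 in one place: hydrogen in place of 3-hydroxypyrrolidin-1-yl on an aromatic carbon. For the measured compounds named here, no pair of measured compounds differs in a single place, so the numbers here give no precedent for a step of this kind. Compound 2 already sits at the floor of what this read-out shows, so the step of no change at the digits printed from compound 2 to compound 3 (within the scatter) is expected to be none beyond the scatter. Compound 3 is therefore estimated at 4%, with a range from -6% to 16%, because in this assay compound 2 gives only 4% and leaves little room for a fall.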

Compound 3, a percentage reported as inhibition, at one concentration (the size of the read-out at that concentration, not a potency): -2%
Compound 3: the middle estimate sits 6 percentage points above what was measured; the range from low to high includes it.
By their numbers in this assay, from the lowest: compounds 3 and 2 (each within the scatter of the next); then compound 1.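

In this assay, for the compounds shown here, hydrogen in place of 3-hydroxypyrrolidin-1-yl on an aromatic carbon, next to the ring nitrogen, gives a number 6 percentage points lower from compound 2 to compound 3 (within the scatter), the first comparison here of two compounds that differ in one place. At this position, then, the read-out does not separate the 3-hydroxypyrrolidin-1-yl group, with its five-membered ring and defined stereocentre, from a plain hydrogen, though both compounds lie so near the floor that a loss could hardly show. Nothing measured here explains this result.

Compound 1 differs from both compounds in more than one place, so it cannot show what this position contributes on its own. Going by these compounds, whether an aminomethyl group, a carboxylic acid or a longer alkyl chain on this aromatic carbon would give a number clear of the floor remains open.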